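Adding a tert-Butoxycarbonyl Group to Compound 1

This account rests on a few compounds, and the source may have more. Where it says the series, first, only, none or still open, it means among the compounds named here.

Compound 1 `FC(F)(F)c1ccc(Nc2nc(NC3CCCNC3)nc3c2CCN(c2ncccc2C(F)(F)F)CC3)cc1` reaches only the assay limit of > 5000 nM in a functional assay on HEK293 cells for antagonist activity at transient receptor potential cation channel subfamily V member 1 (Homo sapiens), read by FLIPR and calcium flux; on this read-out higher numbers stand for weaker inhibition and lower numbers for stronger inhibition. Compound 2 `NC1CCN(c2nc3c(c(Nc4ccc(C(F)(F)F)cc4)n2)CCN(c2ncccc2C(F)(F)F)CC3)C1` gives 3700 nM in this assay.

So compound 1 stands at a limit rather than a number. For the measured compounds named here, the one measured step, an at least 1.3-fold lower number from compound 1 to compound 2 (0.13 log units; that floor lies within the scatter), concerns an exchange of the whole amine-bearing side group and does not bear directly on the cap considered here. Compound 3 `CC(C)(C)OC(=O)N1CCCC(Nc2nc3c(c(Nc4ccc(C(F)(F)F)cc4)n2)CCN(c2ncccc2C(F)(F)F)CC3)C1` carries tert-butoxycarbonyl in place of hydrogen on an amine nitrogen in a ring. Going by the values given here, with no comparable step in hand, no shift beyond the scatter is expected in this assay. Compound 3 is therefore estimated at 6000 nM, between 2000 nM and 20000 nM. That estimate means an expected step that the limit leaves unreadable from compound 1 to compound 3.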

Compound 3, half-maximal inhibitory concentration: 140 nM
Estimate against measurement, compound 3: 43-fold (1.63 log units) above; measured number below the stated range.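

Placing tert-butoxycarbonyl on this amine nitrogen in a ring gives, in this assay, an at least 35-fold lower number from compound 1 to compound 3 (1.55 log units; beyond the scatter). This shows that a hydrogen on this nitrogen is not needed for inhibition, and that the capped compound 3 inhibits far more strongly than compound 1. Compound 1 gives only a limit, so the full size of this step cannot be read: the limit of > 5000 nM in this assay, at which 1 of the 3 values shown sits.

The compounds shown carry only hydrogen or tert-butoxycarbonyl on this nitrogen. As far as these compounds go, how a smaller group such as methyl or acetyl would fare there remains open.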